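The source may hold more compounds than are shown below. What is called first, only, known or untested is meant among the compounds shown, and "the series" means these compounds.

Measured compounds in an ADME assay on MCF-10A cells (Homo sapiens) for inhibition, read by MTT assay, with a stated time of 48 h, tested at 2 uM; on this read-out lower numbers stand for less inhibition and higher numbers for more inhibition at the one concentration tested (going by the name of the read-out):
- compound 1 `Cc1noc(C)c1-c1ccc2c(c1)C(c1ccccc1)NC(=O)N2C`, which gives 6.8%
- compound 2 `Cc1noc(C)c1-c1ccc2c(c1)C(c1ccccc1)N(Cc1ncc(-c3ccccc3)o1)C(=O)N2C`, which gives 3.7%
- compound 3 `Cc1noc(C)c1-c1ccc2c(c1)C(c1ccccc1)N(Cc1nnc(-c3ccccc3)s1)C(=O)N2C`, which gives 3.3%

Compound 2 holds the second highest of the three numbers. Its nearest neighbour is compound 3, its widest gap is to compound 1, and both steps, a number 0.4 percentage points lower from compound 2 to compound 3 (within the scatter) and a number 3.1 percentage points lower from compound 1 to compound 2 (within the scatter), lie within the scatter. All three numbers sit at the low end of the read-out and cannot be told apart.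

Compound 4 `Cc1noc(C)c1-c1ccc2c(c1)C(c1ccccc1)N(Cc1nc(-c3ccc(F)cc3)cs1)C(=O)N2C` is not yet measured. The change from compound 2 is 4-(4-fluorophenyl)-1,3-thiazol-2-yl in place of 5-phenyl-1,3-oxazol-2-yl on a saturated chain carbon bound to an amide-type nitrogen in a ring. The step that bears most directly on it is the exchange of one ring group for another at the same place, a number 0.4 percentage points lower from compound 2 to compound 3 (within the scatter), which stayed within the scatter. The two steps that add a substituent to the amide-type nitrogen in a ring, a number 3.1 percentage points lower from compound 1 to compound 2 (within the scatter) and a number 3.5 percentage points lower from compound 1 to compound 3 (within the scatter), also stayed within the scatter. Among the compounds with values here, no step moves the read-out beyond the scatter, so no step beyond the scatter is expected in this assay for compound 4 either. The estimated step is a number 0.8 percentage points higher from compound 2 to compound 4 (within the scatter). Compound 4 is therefore expected to give about 4.5%, within a range from 0% to 13%.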

Compound 4, a percentage reported as inhibition, at one concentration (the size of the read-out at that concentration, not a potency): 8.5%
For compound 4 the middle estimate is 4 percentage points below the measured one, within the range that was stated.
By their numbers in this assay, from the lowest: compounds 3, 2, 1 and 4 (each within the scatter of the next).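

In this assay, the 4-(4-fluorophenyl)-1,3-thiazol-2-yl group on the saturated chain carbon bound to an amide-type nitrogen in a ring gives a number 4.8 percentage points higher from compound 2 to compound 4 (within the scatter) and a number 5.2 percentage points higher from compound 3 to compound 4 (within the scatter). This third ring group differs from the other two in its hetero atoms and also carries a fluorine, so the position now covers a wider set of aromatic groups, and still no exchange there leaves the scatter of this assay. No measurement is at hand that bears on the result.

The 4-(4-fluorophenyl)-1,3-thiazol-2-yl group differs from both earlier groups in more than one feature, so the shown compounds cannot separate the part of the fluorine from that of the thiazole ring, a question the plain 4-phenyl-1,3-thiazol-2-yl group would address. As far as these compounds go, it also remains open whether anything at this position can move the read-out beyond the scatter, for example a longer chain between the amide-type nitrogen and the ring, or a phenyl ring carrying an amine or a carboxylic acid.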